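Series notes: acyl variation on the shared core

A few compounds are considered here, and "the series" means these few. Any claim that something is new, unique, unknown or untested is made for them only; others in the source may bear on it.

compound 1 `O=C(C1CCC1)N1CC2CC(C1)N2` — an assay on SH-EP1 cells for agonist activity at Neuronal acetylcholine receptor; alpha4/beta2 (Homo sapiens), read by FLIPR and calcium flux; on this read-out lower numbers stand for smaller maximal responses and higher numbers for larger maximal responses: compound 1 gives 100%
compound 2 `O=C([C@H]1C[C@H]1F)N1CC2CC(C1)N2` — this assay: compound 2 gives 110%

Compound 2 and compound 1 sit within the scatter of each other, as the step of a number 10 percentage points higher from compound 1 to compound 2 (within the scatter) shows, so on the numbers shown compound 2 is not set apart. Compound 3 `C[C@@H]1C[C@@H]1C(=O)N1CC2CC(C1)N2` differs from compound 2 thus: methyl in place of fluoro on a saturated ring carbon. Among the compounds with values here, the one measured step, cyclobutyl to 2-fluorocyclopropyl on the carbonyl carbon, touches the same acyl part and stayed within the scatter. A step no larger than the scatter is therefore expected: a number 5 percentage points lower from compound 2 to compound 3 (within the scatter). Compound 3 is estimated at 105%, range 85% to 125%.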

Compound 3, largest response reached (Emax), in percent of the reference or control that the assay uses: 88%
Compound 3: the middle estimate sits 17 percentage points above what was measured, and the stated range covers the measured number.
By their numbers in this assay, from the lowest: compound 3; then compounds 1 and 2 (each within the scatter of the next).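

Within the data shown here, on the saturated ring carbon, methyl in place of fluoro gives the first step in this assay that is beyond the scatter, a number 22 percentage points lower from compound 2 to compound 3 (beyond the scatter), so this position responds to a change of one heavy atom. The step of a number 12 percentage points lower from compound 1 to compound 3 (beyond the scatter), also beyond the scatter, shows that the maximal response is not indifferent to the acyl group on the shared core. No evidence is available that bears on this result.

Open, from the compounds shown here alone, is where an unsubstituted cyclopropyl would fall relative to compound 2 and compound 3. Chloro, hydroxyl or an amine on the same ring carbon would show whether fluoro and methyl mark the ends of a wider range.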